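This account rests on a few compounds, and the source may have more. Where it says the series, first, only, none or still open, it means among the compounds named here.

Compound 1 `CCNC(=O)N1CCN(C(=S)SCc2cn(Cc3ccccc3F)nn2)CC1` gives 2830 nM in a functional assay on MGC-803 cells (Homo sapiens) for cytotoxicity, read by MTT assay, with a stated time of 72 h; on this read-out higher numbers stand for weaker inhibition and lower numbers for stronger inhibition.
Compound 2 `CC(C)NC(=O)N1CCN(C(=S)SCc2cn(Cc3ccccc3F)nn2)CC1` gives 1620 nM in this assay.
Compound 3 `CCNC(=O)N1CCN(C(=S)SCc2cn(Cc3ccc(OC)cc3)nn2)CC1` gives only a limit in this assay, > 128000 nM.

Compound 1 and compound 2 share a core and differ by methyl in place of hydrogen on a saturated chain carbon bound to an amide-type nitrogen and a saturated chain carbon. That change gave a 1.7-fold lower number from compound 1 to compound 2 (0.24 log units; within the scatter). Compound 3 differs from compound 1 in its core by 4-methoxyphenyl in place of 2-fluorophenyl on a saturated chain carbon bound to an aromatic nitrogen, and this change gave an at least 45-fold higher number from compound 1 to compound 3 (1.65 log units; beyond the scatter). The value of compound 3 is a limit, not a number: it sits at the limit of > 128000 nM in this assay, at which 1 of the 3 values shown sits, so this assay reports no figure for it.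

Compound 4 `COc1ccc(Cn2cc(CSC(=S)N3CCN(C(=O)NC(C)C)CC3)nn2)cc1` has not yet been measured. It differs from compound 3 by methyl in place of hydrogen on a saturated chain carbon bound to an amide-type nitrogen and a saturated chain carbon, the same change as that from compound 1 to compound 2, at a place described in the same words. Because the earlier step of a 1.7-fold lower number from compound 1 to compound 2 (0.24 log units; within the scatter) stayed within the scatter, and because compound 3 gives only the limit > 128000 nM, compound 4 is expected to show a step that the limit leaves unreadable from compound 3 to compound 4 and most likely to reach only a limit again. Compound 4 is estimated at 150000 nM, expected between 60000 nM and 400000 nM.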

Compound 4, half-maximal inhibitory concentration: 99200 nM
Compound 4: middle estimate off by 1.5-fold (0.18 log units), on the high side; measured number inside the range.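

On the core of compound 3, ethyl to isopropyl gives an at least 1.2-fold lower number from compound 3 to compound 4 (0.11 log units; that floor lies within the scatter) in this assay, so the change shows no step beyond the scatter on either core, yet this does not show that its size carries over exactly: the same change on two cores in this assay, a 1.7-fold lower number (0.24 log units; within the scatter) from compound 1 to compound 2 and an at least 1.2-fold lower number (0.11 log units; that floor lies within the scatter) from compound 3 to compound 4; the limit leaves it open whether they differ
As far as these compounds go, compound 3 gives only a limit, > 128000 nM, so the true size of this step stays unknown.
The swap of 2-fluorophenyl for 4-methoxyphenyl, by contrast, gives a large step on the isopropyl compounds too, a 61-fold higher number from compound 2 to compound 4 (1.79 log units; beyond the scatter), which shows that a large step appears with both the ethyl and the isopropyl group, though not that the two steps are equal: the same change on two cores in this assay, an at least 45-fold higher number (1.65 log units; beyond the scatter) from compound 1 to compound 3 and a 61-fold higher number (1.79 log units; beyond the scatter) from compound 2 to compound 4; the limit leaves it open whether they differ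

The compounds shown leave open how a longer chain such as butyl, or a ring such as cyclopropyl, would behave in place of the isopropyl group. They also leave open what a plain phenyl or a chlorophenyl would give in place of the 2-fluorophenyl and 4-methoxyphenyl groups.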